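From butyl to methoxy on an aromatic carbon

A few compounds are considered here, and "the series" means these few. Any claim that something is new, unique, unknown or untested is made for them only; others in the source may bear on it.

Measured in a functional assay on MCF7 cells (Homo sapiens) for inhibition, read by MTT assay, with a stated time of 72 h; a lower number here means a stronger inhibitor, a higher number a weaker inhibitor:
Compound 1 `Cc1ccc(NC(=O)C2CCN(C/C=C/c3ccccc3)CC2)cc1`: 30000 nM
Compound 2 `CC(C)c1ccc(NC(=O)C2CCN(C/C=C/c3ccccc3)CC2)cc1`: 9100 nM
Compound 3 `CCCCc1ccc(NC(=O)C2CCN(C/C=C/c3ccccc3)CC2)cc1`: 5870 nM

Compound 3 sits at the low end of these numbers. Its nearest neighbour shows a 1.6-fold lower number from compound 2 to compound 3 (0.19 log units; within the scatter), and its furthest shows a 5.1-fold lower number from compound 1 to compound 3 (0.71 log units; beyond the scatter).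

Compound 4 `COc1ccc(NC(=O)C2CCN(C/C=C/c3ccccc3)CC2)cc1` has methoxy in place of butyl on an aromatic carbon. Among the compounds with values here, no measured compound carries methoxy, so the closest guide is compound 1, with its small methyl group, at 30000 nM. Larger groups came with lower numbers in a 3.3-fold lower number from compound 1 to compound 2 (0.52 log units; beyond the scatter), although the step from isopropyl to butyl stayed within the scatter. A modest rise in this assay is therefore expected. The estimated change is a 3.1-fold higher number from compound 3 to compound 4 (0.49 log units; beyond the scatter). For compound 4 the estimated value is 18000 nM, with an expected range of 7000 nM to 40000 nM.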

Compound 4, half-maximal inhibitory concentration: > 100000 nM
Compound 4 gave a limit, no number; the forecaster's own chance of this, stated with the estimate: 15%; at least 5.5-fold (0.74 log units) between middle value and limit.
By their numbers in this assay, from the lowest: compounds 3 and 2 (each within the scatter of the next); then compound 1. At a limit, above all of these: compound 4.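

Compound 4 gives a limit of the assay, not a number: the limit of > 100000 nM in this assay, at which 1 of the 4 values shown sits. Among the earlier compounds, the change of alkyl group at this position moved the number by modest steps at most, whereas swapping in methoxy gives much larger ones, with an at least 17-fold higher number from compound 3 to compound 4 (1.23 log units; beyond the scatter) and an at least 10-fold higher number from compound 2 to compound 4 (1.04 log units; beyond the scatter). Even against the methyl of compound 1, the change gives an at least 3.3-fold higher number from compound 1 to compound 4 (0.52 log units; beyond the scatter), so an oxygen-linked group here does not follow the trend of the alkyl groups.

Still open, from the compounds shown here alone, is whether a longer chain joined through oxygen, such as butoxy, would behave like methoxy or like butyl. An amine at this position is equally unresolved.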